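The compounds below may be only part of what the source reports. "The series", "measured", "known", "first", "only" and "open" are said of these compounds alone.

In an ADME assay (liver) for metabolic stability, with Liver microsome (Rattus norvegicus) as the target, using microsomes and NADPH, with a stated time of 30 min, tested at 1 uM (a lower number here means slower removal, a higher number faster removal of the compound), compound 1 `NC(=O)c1cccc(-c2cc(C(O)(C(F)(F)F)C(F)(F)F)cnc2N2CCN(S(=O)(=O)c3ccc(N)nc3)CC2)c1` gives 63 mL.min-1.g-1, compound 2 `Nc1ccc(S(=O)(=O)N2CCN(c3ncc(C(O)(C(F)(F)F)C(F)(F)F)cc3-c3cccnc3)CC2)cn1` gives 20 mL.min-1.g-1 and compound 3 `COc1cncc(-c2cc(C(O)(C(F)(F)F)C(F)(F)F)cnc2N2CCN(S(=O)(=O)c3ccc(N)nc3)CC2)c1` gives 58 mL.min-1.g-1. Compound 3 therefore stands within the scatter of one compound and well clear of the other, as the measurements show a 1.1-fold lower number from compound 1 to compound 3 (0.04 log units; within the scatter) and a 2.9-fold higher number from compound 2 to compound 3 (0.46 log units; beyond the scatter). The still unmeasured compound 4 `Nc1ccc(S(=O)(=O)N2CCN(c3ncc(C(O)(C(F)(F)F)C(F)(F)F)cc3-c3cccc4[nH]ncc34)CC2)cn1` carries 1H-indazol-4-yl in place of 5-methoxypyridin-3-yl on an aromatic carbon. Among the compounds with values here, all the measured steps fall at this same place. Besides those two, the data show a 3.2-fold lower number from compound 1 to compound 2 (0.50 log units; beyond the scatter), so exchanges here have ranged from nothing beyond the scatter to modest. None of them involves 1H-indazol-4-yl, and they give no firm direction for it. Two of the three measured compounds sit close together, while compound 2 lies apart at 20 mL.min-1.g-1, so only a slight fall is expected, and nothing beyond the scatter. The estimated step is a 1.4-fold lower number from compound 3 to compound 4 (0.14 log units; within the scatter). For compound 4 the expected value is 42 mL.min-1.g-1, with an estimated range of 17 mL.min-1.g-1 to 100 mL.min-1.g-1.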

Compound 4, intrinsic clearance in microsomes: 93 mL.min-1.g-1
Compound 4: the middle estimate sits 2.2-fold (0.35 log units) below what was measured; the measured number falls inside the stated range.
By their numbers in this assay, from the lowest: compound 2; then compounds 3, 1 and 4 (each within the scatter of the next).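

In this assay, within the data shown here, the 1H-indazol-4-yl, the first group at this position with a five-membered aromatic ring, goes with the two higher compounds and not with compound 2: the exchange gives a 1.6-fold higher number from compound 3 to compound 4 (0.21 log units; within the scatter) and a 1.5-fold higher number from compound 1 to compound 4 (0.17 log units; within the scatter), both inside the usual scatter, but a 4.7-fold higher number from compound 2 to compound 4 (0.67 log units; beyond the scatter) when set against pyridin-3-yl. So 3-carbamoylphenyl, 5-methoxypyridin-3-yl and 1H-indazol-4-yl, three quite different groups, all lie within the scatter of one another, and compound 2 alone stands apart. Nothing available bears on what lies behind this result.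

As far as these compounds go, what stays open is whether any other group reaches the level of compound 2, which gives 20 mL.min-1.g-1, and how a carboxylic acid or an amine would read at this place. Also open, from the compounds shown here alone, is what a methyl group on the ring nitrogen of the 1H-indazol-4-yl would do to the number.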